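The source may hold more compounds than are shown below. What is called first, only, known or untested is meant among the compounds shown, and "the series" means these compounds.

In a physicochemical assay for solubility, in the presence of a further agent that is not named here (a lower number here means a less soluble compound, a higher number a more soluble compound), compound 1 `[O-][n+]1nc(NCCn2cccc2)[n+]([O-])c2ccccc21` gives 61000000 nM, compound 2 `[O-][n+]1nc(NCCN2CCCCC2)[n+]([O-])c2cc(Cl)ccc21` gives 3200000 nM and compound 3 `CCCN(CCC)CCNc1n[n+]([O-])c2ccc(Cl)cc2[n+]1[O-]` gives 600000 nM. Compound 3 stands lowest of the three numbers; its nearest neighbour is compound 2 and its furthest compound 1. Among the measured compounds shown here, the only single-point step recorded is a 5.3-fold lower number from compound 2 to compound 3 (0.73 log units; beyond the scatter). Compound 4 `CCCN(CCC)CCNc1n[n+]([O-])c2ccc(C)cc2[n+]1[O-]` differs from compound 3 by methyl in place of chloro on an aromatic carbon. For the measured compounds named here, no measured pair exchanges the substituent on this aromatic carbon, so the step from compound 2 to compound 3 does not bear on it, and compound 1 differs from compound 2 in two places at once. Going by the values given here, with no comparable step, the change is expected to move the number little, an estimated step of a 1.3-fold higher number from compound 3 to compound 4 (0.12 log units; within the scatter) in this assay. Compound 4 is therefore estimated at 800000 nM, within 250000 nM to 2500000 nM.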

Compound 4, solubility: 38000000 nM
Compound 4: middle estimate off by 48-fold (1.68 log units), on the low side; the measured number lies above the stated range.
By their numbers in this assay, from the lowest: compound 3; then compound 2; then compounds 4 and 1 (each within the scatter of the next).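

In this assay, the substituent on this aromatic carbon moves the number strongly: methyl in place of chloro gives a 63-fold higher number from compound 3 to compound 4 (1.80 log units; beyond the scatter), a large step beside the modest 5.3-fold lower number from compound 2 to compound 3 (0.73 log units; beyond the scatter) on the chain. The two groups match in heavy-atom count, with no hydrogen-bond donors or acceptors, and these counts do not separate them. Nothing measured here accounts for the size of the step. As far as these compounds go, whether the same exchange gives a step of like size with the piperidin-1-yl chain of compound 2 remains open. Also open, from the compounds shown here alone, is how fluoro, methoxy or an amine on this carbon compares with methyl and chloro.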